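Moving the aryl group further out along the chain

This account rests on a few compounds, and the source may have more. Where it says the series, first, only, none or still open, it means among the compounds named here.

Compound 1 `Cc1ccc(CC(C)CNC(=O)/N=C(\N)NCCCc2sc(N)nc2C)cc1` stands second highest of the three numbers measured in a functional assay on HEK293T cells for agonist activity at histamine H2 receptor (Homo sapiens), read by beta-arrestin recruitment (on this read-out higher numbers stand for an effect only at larger amounts of compound and lower numbers for an effect already at smaller amounts), where compound 1 gives 132 nM. Compound 2 `Cc1nc(N)sc1CCCN/C(N)=N/C(=O)NCc1ccccc1` gives 100 nM in this assay, within the scatter of compound 1, so the two cannot be ordered. Among the measured compounds shown here, compound 3 `Cc1nc(N)sc1CCCN/C(N)=N/C(=O)NC(c1ccccc1)c1ccccc1` gives 331 nM, and the step of a 3.3-fold higher number from compound 2 to compound 3 (0.52 log units; beyond the scatter) is the only one-place change measured so far.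

Compound 4 `Cc1nc(N)sc1CCCN/C(N)=N/C(=O)NCC(C)CCCc1ccccc1` differs from compound 1 by phenethyl in place of 4-methylphenyl on a saturated chain carbon, three bonds along the chain from an amide-type nitrogen. For the measured compounds named here, no measured pair shows this kind of change directly. The step of a 3.3-fold higher number from compound 2 to compound 3 (0.52 log units; beyond the scatter) concerns a phenyl entering at a different place, on the chain carbon bound to the amide-type nitrogen, and offers only a loose guide: it shows that a second aromatic ring near that nitrogen costs a modest amount, whereas in compound 4 the single ring is moved outward rather than joined by a second one, and the methyl is lost. No step beyond the scatter is therefore expected in this assay, with the direction uncertain. Compound 4 is estimated at 150 nM in this assay, with a range from 60 nM to 400 nM. The step of a 1.1-fold higher number from compound 1 to compound 4 (0.06 log units; within the scatter) implied by this estimate is expected to remain within the scatter.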

Compound 4, half-maximal effective concentration: 2510 nM
Beside the measured number, compound 4's estimate is 17-fold (1.22 log units) below it; the whole stated range lies below it.
By their numbers in this assay, from the lowest: compounds 2 and 1 (each within the scatter of the next); then compound 3; then compound 4.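

Phenethyl in place of 4-methylphenyl on a saturated chain carbon, three bonds along the chain from an amide-type nitrogen, gives a 19-fold higher number from compound 1 to compound 4 (1.28 log units; beyond the scatter) in this assay, so this position does not tolerate every aryl-bearing group equally. This large step is the biggest seen so far in the series, whereas a 3.3-fold higher number from compound 2 to compound 3 (0.52 log units; beyond the scatter) at a different place was modest, and it arises between two groups that are closely matched on paper: each carries one six-membered aromatic ring of carbon only and no hydrogen-bond donors or acceptors, with 8 heavy atoms against 7. No measurement available here bears on what lies behind this step.

The change lengthens the link to the ring and removes the ring methyl at once, and the compounds shown do not separate these two parts, so a 4-methylphenethyl group or an unsubstituted benzyl group at this place would be needed to tell them apart. As far as these compounds go, it also remains open whether a shorter or longer chain to the ring gives a graded trend or a sharp limit, and whether a carboxylic acid or an amine on the ring is accepted here.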